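This account rests on a few compounds, and the source may have more. Where it says the series, first, only, none or still open, it means among the compounds named here.

Measured so far:
compound 1 `Cc1cc(Nc2cc(N3CCN(C)CC3)nc(Nc3cccc(Cl)c3)n2)n[nH]1` gives 2290 nM in a functional assay on SK-BR-3 cells (Homo sapiens) for antiproliferative activity, read by CCK-8 assay, with a stated time of 72 h; a lower number here means a stronger inhibitor, a higher number a weaker inhibitor
compound 2 `Cc1cc(Nc2cc(N3CCN(C)CC3)nc(Nc3cccc([N+](=O)[O-])c3)n2)n[nH]1` gives 2180 nM in this assay

Compound 2 holds the lower of the two numbers, yet its value sits within the scatter of compound 1. Compound 3 `Cc1cc(Nc2cc(N3CCN(C)CC3)nc(Nc3ccc(C#N)cc3)n2)n[nH]1` differs from compound 2 by 4-cyanophenyl in place of 3-nitrophenyl on a nitrogen on an aromatic ring. For the measured compounds named here, the only measured step, a 1.1-fold lower number from compound 1 to compound 2 (0.02 log units; within the scatter), exchanged one group on that same ring and moved the number hardly at all. Going by the values given here, no step covers a nitrile or this new position, so for compound 3 a change no larger than the scatter is expected: a 1.0-fold higher number from compound 2 to compound 3 (0.00 log units; within the scatter). Compound 3 is therefore estimated at 2200 nM, in a range from 900 nM to 5500 nM.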

Compound 3, half-maximal inhibitory concentration: 883 nM
Beside the measured number, compound 3's estimate is 2.5-fold (0.40 log units) above it; measured number outside the range, below it.
By their numbers in this assay, from the lowest: compound 3; then compounds 2 and 1 (each within the scatter of the next).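

The group on this nitrogen can shift the number after all: 4-cyanophenyl brings a 2.5-fold lower number from compound 2 to compound 3 (0.39 log units; beyond the scatter) and also a 2.6-fold lower number from compound 1 to compound 3 (0.41 log units; beyond the scatter) in this assay whereas the earlier exchange of chloro for nitro stayed within the scatter. This step changes both the group and its place on the ring, so a single exchange cannot be read from it. Nothing available explains the drop.

On these data alone, how 3-cyanophenyl or 4-chlorophenyl would read on this nitrogen stays open, and with it whether the nitrile or its ring position carries the step. As far as these compounds go, an amine or a carboxylic acid at that ring position also remains open.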